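This account rests on a few compounds, and the source may have more. Where it says the series, first, only, none or still open, it means among the compounds named here.

Compound 1 `O=C(O)C[C@@H]1CCCN1c1ccc(Oc2ccccc2)cc1` is the parent of the series. In a functional assay on cells for agonist activity at Free fatty acid receptor 1 (Mus musculus), read by FLIPR and calcium flux, with a stated time of 100 s (a higher number here means that more compound is needed for the effect, a lower number that less compound is needed), compound 1 gives > 16000 nM, which is a limit of the assay rather than a number. Compound 2 `CC(C)(C)c1ccccc1Oc1ccc(N2CCC[C@H]2CC(=O)O)cc1` carries tert-butyl in place of hydrogen on an aromatic carbon. In this assay compound 2 gives > 17000 nM, also a limit. The step that the two limits leave unreadable from compound 1 to compound 2 therefore cannot be sized, since the limit of > 16000 nM in this assay, at which 1 of the 2 values shown sits, and the limit of > 17000 nM in this assay, at which 1 of the 2 values shown sits, both sit at limits. Compound 3 `Cc1ccc(Oc2ccc(N3CCC[C@H]3CC(=O)O)cc2)cc1` differs from compound 1 by methyl in place of hydrogen on an aromatic carbon. With only limits at hand, no step beyond the scatter is expected for a step that the limit leaves unreadable from compound 1 to compound 3. Compound 3 is estimated at 20000 nM, range 8000 nM to 60000 nM, most probably reported again as a limit.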

Compound 3, half-maximal effective concentration: > 33000 nM
Compound 3 ended at the assay's limit (the forecaster's own chance of this, stated with the estimate: 80%); middle value at least 1.6-fold (0.21 log units) away from the limit.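

In this assay compound 3 gives > 33000 nM, a limit and not a number. Compound 1 also stands at a limit, and the step between compound 1 and compound 3 cannot be read. The compounds shown leave open whether any change to the core of compound 1 gives a measurable value in this assay.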